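The source may hold more compounds than are shown below. What is called first, only, known or untested is meant among the compounds shown, and "the series" means these compounds.

Three compounds have been measured in a functional assay on MT4 cells (Homo sapiens) for cytotoxicity; on this read-out lower numbers stand for stronger inhibition and higher numbers for weaker inhibition:

Compound 1 `N#Cc1c(N)cccc1Sc1ccccc1Cl` gives 33000 nM.
Compound 2 `N#Cc1c(N)cccc1Sc1cccc(Cl)c1` gives 53000 nM.
Compound 3 `N#Cc1c(N)cccc1Sc1ccccc1Br` gives 41000 nM.

Compound 1 and compound 2 share the same atoms joined differently; the difference between the two cores is not broken down here. Compound 3 comes from compound 1 by one change, (bromo in place of chloro on an aromatic carbon), and in this assay that change gave a 1.2-fold higher number from compound 1 to compound 3 (0.09 log units; within the scatter). Compound 4 `N#Cc1c(N)cccc1Sc1cccc(Br)c1` comes from compound 2 by the same kind of change, (bromo in place of chloro on an aromatic carbon), but the place differs: in compound 1 the group sits ortho to a large group, in compound 2 meta to a large group. The step from compound 2 to compound 4 is expected to be a 1.1-fold higher number from compound 2 to compound 4 (0.05 log units; within the scatter), because compound 1 to compound 3 gave a 1.2-fold higher number from compound 1 to compound 3 (0.09 log units; within the scatter). Compound 4 is therefore estimated at 60000 nM, between 35000 nM and 100000 nM.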

Compound 4, half-maximal inhibitory concentration: 53000 nM
Estimate against measurement, compound 4: 1.1-fold (0.05 log units) above; the range from low to high includes it.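

In this assay, bromo in place of chloro on an aromatic carbon, meta to a large group, gave no change at the digits printed from compound 2 to compound 4 (within the scatter). The same change on the two cores gave steps that agree with each other: the same change on two cores in this assay, a 1.2-fold higher number (0.09 log units; within the scatter) from compound 1 to compound 3 and no change at the digits printed (within the scatter) from compound 2 to compound 4, 1.2-fold (0.09 log units) apart, within the scatter of two such steps So in these two pairs the swap carries over from one core to the other, but both steps are so small that what carries over is only the lack of a clear effect, and this says nothing about any further core.

On these data alone, it remains open whether a group other than these two halogens, such as an amine or a methoxy, would shift the number at these places. As far as these compounds go, how the compounds behave on any other read-out also remains open.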